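Ester to ether on the shared core

A few compounds are considered here, and "the series" means these few. Any claim that something is new, unique, unknown or untested is made for them only; others in the source may bear on it.

Measured in a functional assay on DU-145 cells (Homo sapiens) for cytotoxicity, read by MTT assay; on this read-out lower numbers stand for stronger inhibition and higher numbers for weaker inhibition:
compound 1 `CC[C@@](C)(O)CC(=O)O[C@H](CC=C(C)C)C1=CC(=O)c2c(O)ccc(O)c2C1=O` gives 12700 nM
compound 2 `CC[C@](C)(O)CC(=O)O[C@H](CC=C(C)C)C1=CC(=O)c2c(O)ccc(O)c2C1=O` gives 20500 nM
compound 3 `CC(C)=CC[C@@H](OC(=O)CCO)C1=CC(=O)c2c(O)ccc(O)c2C1=O` gives 55300 nM

Compound 3 carries the highest number of the three; its nearest neighbour is compound 2 and the furthest is compound 1. The two smaller steps, a 4.4-fold higher number from compound 1 to compound 3 (0.64 log units; beyond the scatter) and a 2.7-fold higher number from compound 2 to compound 3 (0.43 log units; beyond the scatter), are the only ones that touch the acyl part of compound 3, and both point the same way: shrinking the acyl group raised the number modestly. The step of a 1.6-fold higher number from compound 1 to compound 2 (0.21 log units; within the scatter) stays within the scatter, which fits (the fact that compounds 1 and 2 differ only in the configuration as drawn).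

Compound 4 `CC(C)=CC[C@@H](OCC(C)O)C1=CC(=O)c2c(O)ccc(O)c2C1=O` is not yet measured. It differs from compound 3 as follows: 2-hydroxypropyl in place of (2-hydroxyethyl)carbonyl on an oxygen on a saturated carbon. Among the measured compounds shown here, no measured pair changes an ester into an ether, so the two acyl steps give only a loose guide. The direction they share suggests a number at or somewhat above that of compound 3 in this assay, with wide uncertainty.

The estimate for compound 4 in this assay is 65000 nM, expected to fall between 22000 nM and 190000 nM. The step this expectation implies is a 1.2-fold higher number from compound 3 to compound 4 (0.07 log units; within the scatter).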

Compound 4, half-maximal inhibitory concentration: 16100 nM
The estimate for compound 4 lay 4.0-fold (0.61 log units) above the measured number; the measured number lies below the stated range.
By their numbers in this assay, from the lowest: compounds 1, 4 and 2 (each within the scatter of the next); then compound 3.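

In this assay, the ester carbonyl on this oxygen is not needed to hold the number down, since replacing (2-hydroxyethyl)carbonyl with 2-hydroxypropyl gives a 3.4-fold lower number from compound 3 to compound 4 (0.54 log units; beyond the scatter). This runs against the reading of the two acyl steps, in which the short ester of compound 3 carried the higher number. Compound 4 has a short chain too and still sits level with the two larger esters: the comparisons give a 1.3-fold lower number from compound 2 to compound 4 (0.10 log units; within the scatter) and a 1.3-fold higher number from compound 1 to compound 4 (0.10 log units; within the scatter). Across these four compounds, then, the size of the group on this oxygen does not order the numbers on its own, and compound 4 is the one that goes against any such trend.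

Nothing shown here accounts for why the ether sits with compound 1 and compound 2 rather than with compound 3. Still open, going by these compounds, is how far this tolerance extends, for instance to a 2-aminopropyl group or a longer ether chain on the same oxygen, and whether the configuration of the hydroxyl-bearing carbon of 2-hydroxypropyl, which is not defined in the drawing of compound 4, matters.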